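The source may report more compounds than this note shows. Statements on the series, on what has been measured and on what is new or still open speak of the compounds shown alone.

Three compounds have been measured in a functional assay on LNCaP cells (Homo sapiens) for antiproliferative activity, read by propidium iodide staining, with a stated time of 96 h; a higher number here means a weaker inhibitor, a lower number a stronger inhibitor:

Compound 1 `CC(O)(CSc1ccc(C(F)(F)F)cc1)C(=O)Nc1cccc(S(F)(F)(F)(F)F)c1` gives 17500 nM.
Compound 2 `CC(O)(CSc1ccc(OC(F)(F)F)cc1)C(=O)Nc1cccc(S(F)(F)(F)(F)F)c1` gives 10300 nM.
Compound 3 `CC(O)(COc1ccccc1C(F)(F)F)C(=O)Nc1cccc(S(F)(F)(F)(F)F)c1` gives 26300 nM.

Compound 1 and compound 2 differ in one place only: trifluoromethoxy in place of trifluoromethyl on an aromatic carbon. That change brought a 1.7-fold lower number from compound 1 to compound 2 (0.23 log units; within the scatter), a step that stays inside the range expected when the same measurement is repeated, so the two values cannot be put in order with confidence. Compound 3 is built on a different core, and the difference between the core of compound 1 and the core of compound 3 is not broken down here; its value sits within the scatter of compound 1 and beyond the scatter of compound 2.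

Compound 4 `CC(O)(COc1ccccc1OC(F)(F)F)C(=O)Nc1cccc(S(F)(F)(F)(F)F)c1` has not yet been measured. It stands to compound 3 as compound 2 stands to compound 1: trifluoromethoxy in place of trifluoromethyl on an aromatic carbon. The surroundings are not identical, however. In compound 1 the group sits para to a large group, while in compound 3 it sits ortho to a large group, so this is the same kind of change rather than the same change.

Among the compounds with values here, for compound 4 the expectation rests on the pair already measured, because a 1.7-fold lower number from compound 1 to compound 2 (0.23 log units; within the scatter) is the only comparable step available. A step of similar size, a 1.5-fold lower number from compound 3 to compound 4 (0.16 log units; within the scatter), is therefore expected for compound 4, with wider uncertainty since the place differs. The estimated value for compound 4 is 18000 nM, expected to lie between 8000 nM and 40000 nM.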

Compound 4, half-maximal inhibitory concentration: 16100 nM
The estimate for compound 4 lay 1.1-fold (0.05 log units) above the measured number; measured number inside the range.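

In this assay, putting trifluoromethoxy in place of trifluoromethyl on an aromatic carbon, here ortho to a large group, gave a 1.6-fold lower number from compound 3 to compound 4 (0.21 log units; within the scatter), so on this second core the step again stays inside the range expected from repeating the same measurement. Set beside the earlier pair, the two steps agree closely: the same change on two cores in this assay, a 1.7-fold lower number (0.23 log units; within the scatter) from compound 1 to compound 2 and a 1.6-fold lower number (0.21 log units; within the scatter) from compound 3 to compound 4, 1.0-fold (0.02 log units) apart, within the scatter of two such steps. This shows that the change gave a step of similar size on both cores, but it does not show that either group truly outperforms the other, since neither step can be told apart from repeat scatter, and two cores cannot establish a rule for the whole series.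

The compounds shown leave open how the parts of the difference between the two cores contribute, since no single-place pair separates them and no value is set against a step that clearly exceeds the scatter. They also leave open what a group other than these two, such as a nitrile, a carboxylic acid or an amine, would do on the same aromatic ring, and whether a step beyond the scatter could be reached that way.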